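From Compound 2 to Compound 3: a Smaller Terminal Group

The compounds below may be only part of what the source reports. "The series", "measured", "known", "first", "only" and "open" are said of these compounds alone.

Compound 1 `C/N=C(/NC#N)NCCCCCCn1nc(-c2ccccc2)ccc1=O` and compound 2 `CC/N=C(/NC#N)NCCCCn1nc(-c2ccccc2)ccc1=O` share a common core but differ both in chain length and in the group on the amine nitrogen. In a functional assay on the whole organism with Rattus norvegicus as the target (on this read-out lower numbers stand for an effect already at smaller amounts and higher numbers for an effect only at larger amounts of compound), compound 1 reaches only a limit, > 100 mg/kg, and gives no number. In this assay compound 2 gives 60.7 mg/kg. Among the measured compounds shown here, compound 2 therefore holds the only number recorded in this assay; the other entry is a limit (the limit of > 100 mg/kg in this assay, at which 1 of the 2 values shown sits). Compound 1 and compound 2 differ in more than one place. For the measured compounds named here, no single measured step connects them.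

Compound 3 `N#CNC(=N)NCCCCn1nc(-c2ccccc2)ccc1=O` has not yet been measured. It differs from compound 2 in one place: a group of 5 heavy atoms (2 carbon, 3 nitrogen; no ring) in place of a group of 7 heavy atoms (4 carbon, 3 nitrogen; no ring), on an amine nitrogen. Going by the values given here, with no measured step of this kind to lean on, the direction remains open, and a step within the usual scatter, or at most a modest weakening, is expected. Compound 3 is estimated to give 80 mg/kg in this assay, with a range from 30 mg/kg to 200 mg/kg. The step this estimate implies, a 1.3-fold higher number from compound 2 to compound 3 (0.12 log units; within the scatter), is expected to stay within the usual scatter.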

Compound 3, dose for half-maximal effect: 59.3 mg/kg
Estimate against measurement, compound 3: 1.3-fold (0.13 log units) above; measured number inside the range.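

In this assay, putting a group of 5 heavy atoms in place of a group of 7 heavy atoms on this amine nitrogen gives a 1.0-fold lower number from compound 2 to compound 3 (0.01 log units; within the scatter) with the rest of the structure unchanged. At this place, then, the read-out does not separate the two groups, something compound 1 could not show, as it differs from compound 2 in more than one place. Nothing measured here speaks to why the two groups read alike.

The compounds shown leave open whether a larger substituent on this nitrogen, such as a butyl or a benzyl group, would also leave the number within the scatter. Among the compounds shown here, the effect of the saturated chain's length alone also stays unresolved: compound 1 has only a limit, > 100 mg/kg, and no single-place step connects it to the others.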